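From 4-nitrophenyl to 4-fluorophenyl on the carbonyl carbon

A few compounds are considered here, and "the series" means these few. Any claim that something is new, unique, unknown or untested is made for them only; others in the source may bear on it.

Of the compounds shown here, two sharing one core have been measured in a functional assay on KB cells (Homo sapiens) for cytotoxicity; a higher number here means a weaker inhibitor, a lower number a stronger inhibitor. Compound 1 `COc1ccc(S(=O)(=O)N2CCc3cccc(NC(=O)C(C)(C)C)c32)cc1`, with tert-butyl on the carbonyl carbon, gives 359 nM. Compound 2 `COc1ccc(S(=O)(=O)N2CCc3cccc(NC(=O)c4ccc([N+](=O)[O-])cc4)c32)cc1`, with 4-nitrophenyl there, gives 102 nM, the lower of the two numbers.

Next comes compound 3 `COc1ccc(S(=O)(=O)N2CCc3cccc(NC(=O)c4ccc(F)cc4)c32)cc1`, with fluoro in place of nitro on an aromatic carbon, para to a large group: fluoro in place of nitro on an aromatic carbon. Going by the values given here, no measured step exchanges one substituent on this ring for another, so the evidence is thin. Among the compounds with values here, the only measured step, a 3.5-fold lower number from compound 1 to compound 2 (0.55 log units; beyond the scatter), is modest and beyond the scatter, and it replaced tert-butyl with the whole 4-nitrophenyl group. Compound 3 keeps the aromatic ring and changes only its substituent, so a smaller change than that one is expected in this assay, with a slight lean toward a higher number. The expected step is a 1.3-fold higher number from compound 2 to compound 3 (0.11 log units; within the scatter), not clearly beyond the scatter. For compound 3 the estimated value is 130 nM, with an expected range from 45 nM to 400 nM.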

Compound 3, half-maximal inhibitory concentration: 93 nM
For compound 3 the middle estimate is 1.4-fold (0.15 log units) above the measured one; the measured number falls inside the stated range.
By their numbers in this assay, from the lowest: compounds 3 and 2 (each within the scatter of the next); then compound 1.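

In this assay, fluoro in place of nitro on an aromatic carbon, para to a large group, gives a 1.1-fold lower number from compound 2 to compound 3 (0.04 log units; within the scatter), so the two compounds cannot be told apart and the nitro group, with its hydrogen-bond acceptors, is not needed to hold the number seen with compound 2. The advantage over tert-butyl on the carbonyl carbon now appears with two different ring substituents: a 3.5-fold lower number from compound 1 to compound 2 (0.55 log units; beyond the scatter) is joined by a 3.9-fold lower number from compound 1 to compound 3 (0.59 log units; beyond the scatter), and both steps lie beyond the scatter. No measurement here bears on why nitro and fluoro give indistinguishable numbers, or on why either aryl amide differs from the tert-butyl amide.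

Still open is whether this tolerance extends to an unsubstituted phenyl ring, or to an amine or a carboxylic acid at the same ring position, since nitro and fluoro are the only two substituents shown there. Also open, on these data alone, is whether the ring itself matters on the carbonyl carbon, which a cyclohexyl group in place of the 4-fluorophenyl group would test against tert-butyl.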